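Hydroxy on the ring of compound 2: working notes

The source may report more compounds than this note shows. Statements on the series, on what has been measured and on what is new or still open speak of the compounds shown alone.

Measured in a functional assay on the whole organism (Gastrocnemius, strain Sprague-Dawley) for inhibition, with Rattus norvegicus as the target; a lower number here means that less compound is needed, a higher number that more compound is needed for the effect:
- compound 1 `CC(=O)Nc1ccc(-c2ccc(/C=N/N3C(=O)NC(=O)C3O)o2)cc1`: > 0.107 umol/kg
- compound 2 `O=C1CN(/N=C/c2ccc(-c3cccc(C(F)(F)F)c3)o2)C(=O)N1`: 0.05 umol/kg

Going by the values given here, compound 2 holds the only exact number, 0.05 umol/kg. Compound 1 gives a limit, > 0.107 umol/kg, and not a number. The two results therefore offer no exact comparison.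

Compound 3 `O=C1NC(=O)N(/N=C/c2ccc(-c3cccc(C(F)(F)F)c3)o2)C1O` is still unmeasured in this assay. It keeps the rest of compound 2 and changes in one place: hydroxy in place of hydrogen on a saturated ring carbon. This puts hydroxy in place of hydrogen on a saturated ring carbon, turning 2,4-dioxoimidazolidin-1-yl into 5-hydroxy-2,4-dioxoimidazolidin-1-yl.

Among the compounds with values here, no measured step isolates this change, so any size given for it remains an expectation. The 5-hydroxy-2,4-dioxoimidazolidin-1-yl group also occurs in compound 1, which gives the limit > 0.107 umol/kg. On that slender basis, a moderate move towards more compound needed is expected, somewhat beyond the scatter, with no change also possible. The expected step is a 3.0-fold higher number from compound 2 to compound 3 (0.48 log units; beyond the scatter). The estimate for compound 3 is 0.15 umol/kg, with an expected range from 0.04 umol/kg to 0.6 umol/kg.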

Compound 3, dose for half-maximal effect: 0.096 umol/kg
Compound 3: the middle estimate sits 1.6-fold (0.19 log units) above what was measured; the range from low to high includes it.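

In this assay, hydroxy in place of hydrogen on a saturated ring carbon, next to the ring nitrogen, gives a 1.9-fold higher number from compound 2 to compound 3 (0.28 log units; within the scatter). Going by these compounds alone, this position therefore carries the hydroxy group without a shift that can be told from the usual scatter, at least with the core of compound 2, and the single step is the first direct reading of this change. Compound 1 carries the same 5-hydroxy-2,4-dioxoimidazolidin-1-yl group but offers only a limit and not a number, so compound 3 supplies the only exact reading for this group: the limit of > 0.107 umol/kg in this assay, at which 1 of the 3 values shown sits.

The compounds shown leave open whether this ring carbon would take anything larger or of another kind, such as a methoxy, an amine or a carboxylic acid, as it takes hydroxy here. They also leave open whether the same step between 2,4-dioxoimidazolidin-1-yl and 5-hydroxy-2,4-dioxoimidazolidin-1-yl would read alike on the core of compound 1, where the other end of the molecule differs.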